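Trimming the Amine Substituent Down to a Benzyl Group

A few compounds are considered here, and "the series" means these few. Any claim that something is new, unique, unknown or untested is made for them only; others in the source may bear on it.

Three compounds share one core and differ only in the group attached to an amine nitrogen. In a functional assay on CHO cells for activation of 5-hydroxytryptamine receptor 1D (Homo sapiens), read by GTPgammaS binding (on this read-out higher numbers stand for larger maximal responses and lower numbers for smaller maximal responses), compound 1 `c1ccc2c(c1)CCC2NC1CCN(CCCc2c[nH]c3ccc(-n4cnnc4)cc23)CC1` gives 68%, compound 2 `OCCC(NC1CCN(CCCc2c[nH]c3ccc(-n4cnnc4)cc23)CC1)c1ccccc1` gives 100%, and compound 3 `CC(=O)Nc1ccc([C@H](C)NCC2CCN(CCCc3c[nH]c4ccc(-n5cnnc5)cc34)CC2)cc1` gives 99%. Compound 3 therefore sits together with compound 2 at the top of the three numbers, the two lying within the scatter of each other, while both stand beyond the scatter above compound 1.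

Compound 4 `c1ccc(CNCC2CCN(CCCc3c[nH]c4ccc(-n5cnnc5)cc34)CC2)cc1` is not yet measured. It differs from compound 3 by benzyl in place of 1-(4-acetamidophenyl)ethyl on an amine nitrogen.

Going by the values given here, only one measured step changes a group on this amine nitrogen: a number 32 percentage points higher from compound 1 to compound 2 (beyond the scatter). That step shows that swapping the group on this nitrogen can move the maximal response a long way, but it involves different groups, so it gives no direct guide to the present change. Given that, the most reasonable expectation is a moderate drop, a number 14 percentage points lower from compound 3 to compound 4 (beyond the scatter), with the value of compound 4 estimated at 85% within a range from 60% to 100%.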

Compound 4, largest response reached (reported as efficacy), in percent of the reference or control that the assay uses: 101%
Estimate against measurement, compound 4: 16 percentage points below; the measured number lies above the stated range.
By their numbers in this assay, from the lowest: compound 1; then compounds 3, 2 and 4 (each within the scatter of the next).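

In this assay, the two compounds cannot be told apart when benzyl takes the place of 1-(4-acetamidophenyl)ethyl (a number 2 percentage points higher from compound 3 to compound 4 (within the scatter)), so the defined stereocentre, the hydrogen-bond donor and the hydrogen-bond acceptor that leave with this group are not required for a full maximal response. On the saturated ring carbon, (benzylamino)methyl and (3-hydroxy-1-phenylpropyl)amino also cannot be told apart (a number 1 percentage points higher from compound 2 to compound 4 (within the scatter)), while (2,3-dihydro-1H-inden-1-yl)amino stands clearly lower (a number 33 percentage points higher from compound 1 to compound 4 (beyond the scatter)). No measurement shown accounts for these results.

As far as these compounds go, it remains open whether the response survives a fluorine or methoxy group on the benzyl ring, or a longer chain between that ring and the amine nitrogen. From the compounds shown here alone, these numbers describe only the largest response reached, so how much of each compound is needed to reach it also remains open.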